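Methoxy to hydroxy on the shared core

A few compounds are considered here, and "the series" means these few. Any claim that something is new, unique, unknown or untested is made for them only; others in the source may bear on it.

In an ADME assay on L6 cells (Rattus norvegicus) for cytotoxicity (a lower number here means a stronger inhibitor, a higher number a weaker inhibitor), compound 1 `CC(C)NC(=N)c1ccc(-c2cc3ccc(C(=N)NC(C)C)cc3o2)cc1` gives > 199000 nM as a limit of the assay and not a number. Within the data shown here, compound 2 `COc1cc(C2=NCCN2)cc2cc(-c3ccc(C4=NCCN4)cc3)oc12` gives 19900 nM and is the only compound with a number so far, so there is no measured neighbour to rank it against. Compound 3 `Oc1cc(C2=NCCN2)cc2cc(-c3ccc(C4=NCCN4)cc3)oc12` is still unmeasured. The change is hydrogen in place of methyl on an oxygen on an aromatic ring as its counted difference: hydrogen in place of methyl on an oxygen on an aromatic ring, or methoxy to hydroxy. Among the measured compounds shown here, no measured step is available to size this change. A small shift in this assay is expected, probably within the usual scatter, with a slight lean toward weaker inhibition. The expected 1.3-fold higher number from compound 2 to compound 3 (0.10 log units; within the scatter) is small for that reason. For compound 3 the estimate is 25000 nM with an expected range from 8000 nM to 80000 nM around it.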

Compound 3, half-maximal inhibitory concentration: > 203000 nM
Compound 3 gave a limit, no number; the forecaster's own chance of this, stated with the estimate: 12%; at least 8.1-fold (0.90 log units) between middle value and limit.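

In this assay, among these compounds, hydrogen in place of methyl on an oxygen on an aromatic ring gives the first sized step at this position, an at least 10-fold higher number from compound 2 to compound 3 (1.00 log units; beyond the scatter). Compound 3 gives > 203000 nM, which is a limit of the assay and not a number, so the step gives only a lower bound on the size of the change: the limit of > 203000 nM in this assay, at which 1 of the 3 values shown sits. The methoxy to hydroxy change is therefore not silent on the shared core in this assay, and it takes the series from a measured number to a limit.

As far as these compounds go, whether ethoxy or a longer chain on the oxygen, or an amine in place of it, would keep a measurable number remains open. This single step also leaves open whether the same change has the same effect on any other core.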